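A Terminal Amine Swap on Two Related Cores

The source may hold more compounds than are shown below. What is called first, only, known or untested is meant among the compounds shown, and "the series" means these compounds.

Compound 1 `CN(C)CCCCCSC1=Nc2ccccc2C(CC(=O)NCc2ccccc2)N1c1ccc(-c2ccccc2)cc1` and compound 2 `O=C(CC1c2ccccc2N=C(SCCCCCN2CCCC2)N1c1ccc(-c2ccccc2)cc1)NCc1ccccc1` share one core and differ only by pyrrolidin-1-yl in place of dimethylamino on a saturated chain carbon, five bonds along the chain from a sulfur. In a functional assay on A549 cells (Homo sapiens) for cytotoxicity, read by MTT assay, with a stated time of 48 h (on this read-out higher numbers stand for weaker inhibition and lower numbers for stronger inhibition), compound 1 gives 18100 nM, while compound 2 gives 14900 nM, so that a 1.2-fold lower number from compound 1 to compound 2 (0.08 log units; within the scatter). Compound 3 `CN(C)CCCCCSC1=Nc2ccccc2C(CC(=O)NCc2ccccc2)N1c1ccccc1` rests on a different core, which is set apart from that of compound 1 by hydrogen in place of phenyl on an aromatic carbon; in this assay compound 3 gives 138000 nM, and a 7.6-fold higher number from compound 1 to compound 3 (0.88 log units; beyond the scatter). Compound 4 `O=C(CC1c2ccccc2N=C(SCCCCCN2CCCC2)N1c1ccccc1)NCc1ccccc1` is obtained from compound 3 by pyrrolidin-1-yl in place of dimethylamino on a saturated chain carbon, five bonds along the chain from a sulfur, the same change at the same place as that between compound 1 and compound 2. A step of similar size is expected from compound 3 to compound 4 in this assay, namely a 1.2-fold lower number from compound 3 to compound 4 (0.08 log units; within the scatter), because the earlier step of a 1.2-fold lower number from compound 1 to compound 2 (0.08 log units; within the scatter) stayed within the scatter. Compound 4 is therefore estimated to give about 115000 nM, most likely between 50000 nM and 300000 nM.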

Compound 4, half-maximal inhibitory concentration: 98100 nM
Estimate against measurement, compound 4: 1.2-fold (0.07 log units) above, within the range that was stated.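

In this assay, pyrrolidin-1-yl in place of dimethylamino again leaves the number within the scatter, the new step being a 1.4-fold lower number from compound 3 to compound 4 (0.15 log units; within the scatter), and it carries from one core to the other: the same change on two cores in this assay, a 1.2-fold lower number (0.08 log units; within the scatter) from compound 1 to compound 2 and a 1.4-fold lower number (0.15 log units; within the scatter) from compound 3 to compound 4, 1.2-fold (0.06 log units) apart, within the scatter of two such steps. Hydrogen in place of phenyl also carries over, with a 6.6-fold higher number from compound 2 to compound 4 (0.82 log units; beyond the scatter) matching the earlier step: the same change on two cores in this assay, a 7.6-fold higher number (0.88 log units; beyond the scatter) from compound 1 to compound 3 and a 6.6-fold higher number (0.82 log units; beyond the scatter) from compound 2 to compound 4, 1.2-fold (0.06 log units) apart, within the scatter of two such steps. Within the data shown here, this shows that the two changes combine consistently across these four compounds, but it covers only this one pair of cores in this one cell assay and does not show that the amine swap would stay as small on any other core.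

The compounds shown leave open whether other terminal amines, such as piperidine or morpholine, or a longer chain would behave alike. They also leave open what a chlorine or a methoxy group would do in place of the phenyl.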